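The source may hold more compounds than are shown below. What is called first, only, known or untested is meant among the compounds shown, and "the series" means these compounds.

Measured compounds:
Compound 1 `O=c1cc(CSC(=S)N2CCCCC2)oc2cc(Cl)ccc12`: in a functional assay on LM7 cells (Homo sapiens) for antiproliferative activity, read by MTT assay, with a stated time of 72 h (on this read-out higher numbers stand for weaker inhibition and lower numbers for stronger inhibition), compound 1 gives 13800 nM.
Compound 2 `O=c1cc(CSC(=S)N2CCCC2)oc2ccccc12`: in this assay compound 2 gives 40000 nM.
Compound 3 `O=c1cc(CSC(=S)N2CCCCC2)oc2ccccc12`: in this assay compound 3 reaches only a limit, > 25000 nM.

Compound 3 thus stands at the limit of the assay, (the limit of > 25000 nM in this assay, at which 1 of the 3 values shown sits), and no number is known for it; it sits at the weak end of the three. Compound 4 `O=c1c(Cl)c(CSC(=S)N2CCCCC2)oc2ccccc12` differs from compound 3 by chloro in place of hydrogen on an aromatic carbon. Two measured steps end at compound 3. The step of an at least 1.8-fold higher number from compound 1 to compound 3 (0.25 log units; that floor lies within the scatter) is the only one that concerns a chloro on an aromatic carbon of the shared core, though in compound 1 that chloro stands on a different aromatic carbon. The step that the limit leaves unreadable from compound 2 to compound 3 concerns the ring on the thiocarbonyl carbon, not the change made here, and its size cannot be read. The change to compound 4 runs the chloro step in reverse, so a lower number is expected for compound 4, though its placement is new and the floor of the measured step lies within the scatter. The expected step for compound 4 is an at least 2.0-fold lower number from compound 3 to compound 4 (0.31 log units; beyond the scatter). Compound 4 is therefore estimated at 12000 nM, with a range from 4000 nM to 40000 nM.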

Compound 4, half-maximal inhibitory concentration: 3300 nM
For compound 4 the middle estimate is 3.6-fold (0.56 log units) above the measured one, and the stated range ends above it.
By their numbers in this assay, from the lowest: compound 4; then compound 1; then compound 2.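

In this assay, chloro in place of hydrogen on this aromatic carbon, two atoms from the ring oxygen, gives an at least 7.5-fold lower number from compound 3 to compound 4 (0.87 log units; beyond the scatter) and so shows that this single change on the shared core is enough for a step beyond the scatter. The earlier chloro step, with the chloro on a different aromatic carbon, was an at least 1.8-fold higher number from compound 1 to compound 3 (0.25 log units; that floor lies within the scatter) and did not show this, so the placement shown here is the first to give a clear step. The new step is only a floor, since compound 3 holds a limit and not a number: the limit of > 25000 nM in this assay, at which 1 of the 4 values shown sits.

From the compounds shown here alone, it remains open whether bromo, fluoro, methyl or an amine on this same carbon would give a comparable step. Going by these compounds, it is also open whether chloro here would give the same step with pyrrolidin-1-yl in place of piperidin-1-yl on the thiocarbonyl carbon.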